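The source may report more compounds than this note shows. Statements on the series, on what has been measured and on what is new or still open speak of the compounds shown alone.

Of the compounds shown here, three from this series have been measured. Compound 1 `O=C(NCCO)c1cc(-c2ccc(Cl)cc2Cl)n[nH]1` gives 44 nM in an assay on isolated protein for inhibition of alkaline phosphatase, tissue-nonspecific isozyme (Homo sapiens); on this read-out higher numbers stand for weaker inhibition and lower numbers for stronger inhibition. Compound 2 `CC(C)NC(=O)c1cc(-c2ccc(Cl)cc2Cl)n[nH]1` gives 51 nM. Compound 3 `O=C(NCCO)c1cc(-c2cc(F)c(Cl)cc2Cl)n[nH]1` gives 100 nM, the highest of the three numbers, though its gap to compound 2 is within the scatter and only its gap to compound 1 lies beyond it. The steps seen so far are a 1.2-fold higher number from compound 1 to compound 2 (0.06 log units; within the scatter) and a 2.3-fold higher number from compound 1 to compound 3 (0.36 log units; beyond the scatter).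

Compound 4 `CN(C)C(=O)c1cc(-c2cc(F)c(Cl)cc2Cl)n[nH]1` differs from compound 3 in one place: dimethylamino in place of (2-hydroxyethyl)amino on a carbonyl carbon. For the measured compounds named here, the step that bears on this is the one from compound 1 to compound 2, where the group on the amide-type nitrogen was also exchanged and the number moved only within the scatter. Going by the values given here, no measured pair shows the dimethylamino group itself. On this basis, compound 4 is expected to sit close to compound 3, with a step of a 1.1-fold higher number from compound 3 to compound 4 (0.04 log units; within the scatter) expected in this assay, that is, none beyond the scatter. Compound 4 is therefore estimated at 110 nM, within a range from 40 nM to 300 nM.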

Compound 4, half-maximal inhibitory concentration: 324 nM
The estimate for compound 4 lay 2.9-fold (0.47 log units) below the measured number, and the stated range ends below it.
By their numbers in this assay, from the lowest: compounds 1, 2 and 3 (each within the scatter of the next, the first and the last beyond it); then compound 4.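

The exchange of (2-hydroxyethyl)amino for dimethylamino on the carbonyl carbon gives a 3.2-fold higher number from compound 3 to compound 4 (0.51 log units; beyond the scatter) in this assay, so this position does respond to the group placed there, even though a 1.2-fold higher number from compound 1 to compound 2 (0.06 log units; within the scatter) had shown a change here that stayed within the scatter. What sets this exchange apart in the counts is that the entering dimethylamino group carries no hydrogen-bond donors or acceptors, while the leaving group carries both. Nothing measured here gives a reason for the step.

The compounds shown leave open whether the loss of the amide hydrogen or the loss of the hydroxyl matters here, a question that methylamino or N-methyl-(2-hydroxyethyl)amino on the same carbonyl carbon would help to separate. They also leave open whether dimethylamino has a similar effect on the core of compound 1, which lacks the fluoro group.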